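A few compounds are considered here, and "the series" means these few. Any claim that something is new, unique, unknown or untested is made for them only; others in the source may bear on it.

Measured compounds:
compound 1 `CC1(c2ccccc2)CC(=O)N(CC(=O)N2CCN(c3ccccc3F)CC2)C1=O` — 300 mg/kg
compound 2 `Cc1cccc(N2CCN(C(=O)CN3C(=O)CC(C)(c4ccccc4)C3=O)CC2)c1` — "not active" (no number reported)
compound 3 `CC1(c2ccccc2)CC(=O)N(CC(=O)N2CCN(c3ccc(F)cc3)CC2)C1=O` — "not active" (no number reported)

In a functional assay on the whole organism (strain CD-1) with Mus musculus as the target, with a stated time of 2 h (on this read-out lower numbers stand for an effect already at smaller amounts and higher numbers for an effect only at larger amounts of compound), compound 1 gives 300 mg/kg. It is the only one of the three with a number at all. For compound 2 the result is "not active" (no number reported), with no number reported. For compound 3 the result is likewise "not active" (no number reported), again without a number. So compound 1 stands alone as the one compound with a measured dose, and nothing can be said about how far it lies from the other two.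

Compound 4 `CC1(c2ccccc2)CC(=O)N(CC(=O)N2CCN(c3cccc(C(F)(F)F)c3)CC2)C1=O` has not been measured yet. It differs from compound 1 in one place: 3-(trifluoromethyl)phenyl in place of 2-fluorophenyl on an amine nitrogen in a ring. Among the compounds with values here, no pair of measured compounds shows what such a change does, and the two neighbours of compound 1 gave no number. The step from compound 1 to compound 4 in this assay is therefore expected to be small, within the scatter, as no change at the digits printed from compound 1 to compound 4 (within the scatter). Compound 4 is estimated at 300 mg/kg, in a range from 100 mg/kg to 1000 mg/kg, with a real chance that only "not active" is reported.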

Compound 4, minimum effective dose: "not active" (no number reported)
Compound 4 has no reported number here, so the estimate cannot be set against anything.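

In this assay, within the data shown here, compound 4 gives no number, so no step from compound 1 to compound 4 can be read. The compounds shown leave open how far 3-(trifluoromethyl)phenyl and 2-fluorophenyl differ in their effect on the dose. Nothing measured here explains this result.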